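Replacing the amine group of compound 2 with ethylcarbamoyl

This account rests on a few compounds, and the source may have more. Where it says the series, first, only, none or still open, it means among the compounds named here.

Measured so far in a functional assay on CCRF-CEM cells (Homo sapiens); on this read-out lower numbers stand for higher toxicity in this test and higher numbers for lower toxicity in this test

- Compound 1 `COC(=O)CC(=O)NC1=CS(=O)(=O)O[C@@]12[C@@H](CO[Si](C)(C)C(C)(C)C)O[C@@H](n1cc(C)c(=O)n(C)c1=O)[C@@H]2O[Si](C)(C)C(C)(C)C` gives 29700 nM
- Compound 2 `Cc1cn([C@@H]2O[C@H](CO[Si](C)(C)C(C)(C)C)[C@@]3(OS(=O)(=O)C=C3NCCC(=O)OCc3ccccc3)[C@H]2O[Si](C)(C)C(C)(C)C)c(=O)n(C)c1=O` gives > 250000 nM (a limit of the assay)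

Compound 2 stands at > 250000 nM in this assay and this is a limit, not a number.

Compound 3 `CCNC(=O)NC1=CS(=O)(=O)O[C@@]12[C@@H](CO[Si](C)(C)C(C)(C)C)O[C@@H](n1cc(C)c(=O)n(C)c1=O)[C@@H]2O[Si](C)(C)C(C)(C)C` has not yet been measured. It differs from compound 2 by one group ethylcarbamoyl in place of 2-(benzyloxycarbonyl)ethyl on an amine nitrogen with ethylcarbamoyl in place of 2-(benzyloxycarbonyl)ethyl on an amine nitrogen.

For the measured compounds named here, only one measured step bears on this change. It is an at least 8.4-fold higher number from compound 1 to compound 2 (0.92 log units; beyond the scatter) and it came when 2-(benzyloxycarbonyl)ethyl entered at this same place. Compound 3 loses that group, so it may move back toward compound 1 at 29700 nM on this evidence, though ethylcarbamoyl itself has never been tested here. A single step is thin support, so the range must stay wide.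

The expected change is an at least 4.1-fold lower number from compound 2 to compound 3 (0.61 log units; beyond the scatter) in this assay and it points toward lower numbers, which here mean higher toxicity. For compound 3 the estimate is 60000 nM with an expected range from 12000 nM to 250000 nM in this read-out.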

Compound 3, half-maximal cytotoxic concentration: 4260 nM
Compound 3: middle estimate off by 14-fold (1.15 log units), on the high side; the whole stated range lies above it.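

In this assay, the group on this amine nitrogen can do more than raise the number, as ethylcarbamoyl in place of 2-(benzyloxycarbonyl)ethyl gives an at least 58-fold lower number from compound 2 to compound 3 (1.76 log units; beyond the scatter). As far as these compounds go, compound 2 stands at a limit of the assay, so the true size of that step stays unknown: the limit of > 250000 nM in this assay, at which 1 of the 3 values shown sits. The group on the carbonyl carbon also counts, since ethylamino in place of (methoxycarbonyl)methyl gives a 7.0-fold lower number from compound 1 to compound 3 (0.84 log units; beyond the scatter), so a carbonyl on this nitrogen does not by itself set the number.

From the compounds shown here alone, with only these three compounds, it remains open whether the higher toxicity of compound 3 follows the nitrogen of ethylamino or its ethyl chain, a question that a methylamino group, a longer chain such as butylamino or a dimethylamino group with no amide hydrogen on that nitrogen could help to settle. Going by these compounds, it is also open whether a carbonyl is needed at all at this place, which a plain ethyl group on the amine nitrogen or a free carboxylic acid in place of the benzyl ester of compound 2 would begin to test.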